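This account rests on a few compounds, and the source may have more. Where it says the series, first, only, none or still open, it means among the compounds named here.

Compound 1 `COC(=O)C1=C(C)N=C(C)/C(=C(\O)OC)C1c1ccc(I)cc1` stands at the highest of the two numbers recorded in a functional assay (muscle tissue) with Cavia porcellus as the target (on this read-out higher numbers stand for an effect only at larger amounts of compound and lower numbers for an effect already at smaller amounts), where compound 1 gives 22900 nM. Its nearest neighbour, compound 2 `COC(=O)C1=C(C)N=C(C)/C(=C(\O)OC)C1c1cc([N+](=O)[O-])ccc1O`, lies far lower, a gap well beyond the scatter, and in this assay compound 2 gives 100 nM. The two are not a single-change pair, so their values show only how wide the range on this core can be.

Compound 3 `COC(=O)C1=C(C)N=C(C)/C(=C(\O)OC)C1c1ccc(Cl)cc1Cl` is not yet measured. It differs from compound 1 in one place: 2,4-dichlorophenyl in place of 4-iodophenyl on a saturated ring carbon. Going by the values given here, no measured step of this kind exists here, so the direction rests on judgment. The account expects compound 3 to show an effect at smaller amounts than compound 1, with a step from compound 1 to compound 3 of a 38-fold lower number from compound 1 to compound 3 (1.58 log units; beyond the scatter), well beyond the scatter. In this assay compound 3 is estimated at 600 nM, within a range from 60 nM to 6000 nM.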

Compound 3, half-maximal effective concentration: 640 nM
Beside the measured number, compound 3's estimate is 1.1-fold (0.03 log units) below it, within the range that was stated.
By their numbers in this assay, from the lowest: compound 2; then compound 3; then compound 1.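

In this assay, going by these compounds alone, the exchange of 4-iodophenyl for 2,4-dichlorophenyl on the saturated ring carbon gives a 36-fold lower number from compound 1 to compound 3 (1.55 log units; beyond the scatter) and is the first change here that can be read at a single place. It shows that the aryl group on this carbon, with the rest of the core of compound 1 unchanged, is enough by itself to move the number far beyond the scatter. Nothing at hand accounts for the size or direction of this step.

The change replaces the iodine and adds a second halogen at once, so the compounds shown do not separate the two, and a 4-chlorophenyl or 2-chlorophenyl group alone would be needed to do so. Going by these compounds, how a 4-aminophenyl or 4-methoxyphenyl group would read on this carbon also stays open.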